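A few compounds are considered here, and "the series" means these few. Any claim that something is new, unique, unknown or untested is made for them only; others in the source may bear on it.

Working notes on the series. Compound 1 `Cc1cc(C)cc(Nc2nccc(-c3ccccn3)n2)c1` is the reference point; in a functional assay for inhibition, with Homo sapiens as the target (on this read-out lower numbers stand for stronger inhibition and higher numbers for weaker inhibition), compound 1 gives 100 nM, the lowest of the three numbers at hand. Compound 3 `Cc1cccc(Nc2nccc(-c3ccccn3)n2)c1` gives 700 nM in this assay, and compound 2 `CN(C)c1cccc(Nc2nccc(-c3cccs3)n2)c1` gives 2400 nM. Among the compounds with values here, the only single-point step among the measured compounds is a 7.0-fold higher number from compound 1 to compound 3 (0.85 log units; beyond the scatter), which concerns a methyl on the aniline portion and not the aromatic group attached to the core.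

Compound 4 `Cc1cc(C)cc(Nc2nccc(-c3ccco3)n2)c1` differs from compound 1 by furan-2-yl in place of pyridin-2-yl on an aromatic carbon. Within the data shown here, no measured step bears directly on this exchange. Compound 2 differs from compound 1 in two places at once, one of them being the aromatic group on the core, so its higher number cannot be assigned to either change alone; it only shows that altering that part of the molecule, together with the aniline substitution, can cost potency. A step in the weaker direction, beyond the scatter but not large, is therefore expected for a 4.0-fold higher number from compound 1 to compound 4 (0.60 log units; beyond the scatter). Compound 4 is estimated at 400 nM, with a range from 100 nM to 2000 nM.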

Compound 4, half-maximal inhibitory concentration: 700 nM
Compound 4: the middle estimate sits 1.8-fold (0.24 log units) below what was measured, within the range that was stated.
By their numbers in this assay, from the lowest: compound 1; then compounds 3 and 4 (each within the scatter of the next); then compound 2.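

In this assay the exchange of pyridin-2-yl for furan-2-yl on the aromatic carbon next to the ring nitrogen gives a 7.0-fold higher number from compound 1 to compound 4 (0.85 log units; beyond the scatter) and so counts as a step in the weaker direction. Within the data shown here, this is the only reading of the aromatic group at this position with nothing else changed; in compound 2 a second change comes with it, so the group's share could not be separated there. No measurement at hand accounts for this step.

On these data alone, whether pyridin-2-yl owes its lower number to its ring nitrogen stays open, and phenyl or pyridin-3-yl at this position would speak to that. Also open, as far as these compounds go, is whether the same exchange costs as much when the aniline portion carries a single methyl, as in compound 3.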